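The compounds below may be only part of what the source reports. "The series", "measured", "known", "first", "only" and "open" are said of these compounds alone.

Measured so far:
compound 1 `c1ccc(-c2ccccc2OCc2c[nH]cn2)cc1` — an assay for binding affinity to Alpha-1B adrenergic receptor (Homo sapiens); a higher number here means a weaker inhibitor, a lower number a stronger inhibitor: 5890 nM
compound 2 `CCN(CC)C(=O)c1ccccc1OCC1=NCCN1` — this assay: < 30200 nM

Compound 1 gives a numerical value in this assay, 5890 nM. On these data alone, for compound 2 the result is only a limit, < 30200 nM, so where it truly stands is unknown; this is recorded as the limit of < 30200 nM in this assay, at which 1 of the 2 values shown sits. Within the data shown here, no measured pair differing in one place exists here, so no step size between measured compounds can be given.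

Compound 3 `CCN(CC)C(=O)c1ccccc1OCc1c[nH]cn1` is not yet measured. It differs from compound 2 by a group of 5 heavy atoms (3 carbon, 2 nitrogen; one five-membered aromatic ring with 2 hetero atoms) in place of a group of 5 heavy atoms (3 carbon, 2 nitrogen; one five-membered non-aromatic ring with 2 hetero atoms), on a saturated chain carbon bound to an oxygen on an aromatic ring. The 1H-imidazol-4-yl that enters is the same group that compound 1 carries on its own core, where compound 1 reaches 5890 nM, but compound 1 and compound 3 share nothing else that the data count, so only a loose expectation follows.

With compound 2 standing at a limit, the direction of the step from compound 2 to compound 3 cannot be anchored; he expects, at most, a modest gain in affinity, a step that the limit leaves unreadable from compound 2 to compound 3, with a real chance that compound 3 again returns only a limit. His estimate for compound 3 in this assay is 12000 nM, within a range from 2500 nM to 40000 nM.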

Compound 3, half-maximal inhibitory concentration: < 30200 nM
Compound 3 gave a limit, no number (the forecaster's own chance of this, stated with the estimate: 40%); the middle value lies beyond the limit too.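

In this assay compound 3 gives only a limit, < 30200 nM. Compound 2 also rests on a limit, so no step can be read between compound 2 and compound 3: the limit of < 30200 nM in this assay, at which 2 of the 3 values shown sit.

The compounds shown leave open where compound 2 and compound 3 truly stand, and whether the 1H-imidazol-4-yl in place of the five-membered non-aromatic ring changes the result at all.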